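A few compounds are considered here, and "the series" means these few. Any claim that something is new, unique, unknown or untested is made for them only; others in the source may bear on it.

This account follows a small set of amides built on a shared core and tested in a functional assay on HCT-116 cells (Homo sapiens) for antiproliferative activity, read by MTT assay, with a stated time of 48 h; on this read-out higher numbers stand for weaker inhibition and lower numbers for stronger inhibition. Within the data shown here, compound 2 `O=C(Nc1cc(Sc2ncn[nH]2)c(O)c2ccccc12)c1ccc(Cl)cc1` is the only member that gives a number: in this assay compound 2 gives 43300 nM. Compound 3 `Cc1cccc(C(=O)Nc2cc(Sc3ncn[nH]3)c(O)c3ccccc23)c1` carries a 3-methylphenyl in place of the 4-chlorophenyl on the carbonyl carbon. In this assay compound 3 gives > 100000 nM, a limit of the assay rather than a number. The step is an at least 2.3-fold higher number from compound 2 to compound 3 (0.36 log units; beyond the scatter). Compound 1 `O=C(/C=C/c1ccc([N+](=O)[O-])cc1)Nc1cc(Sc2ncn[nH]2)c(O)c2ccccc12` places a double bond outside aromatic rings between the carbonyl and its aryl ring. In this assay compound 1 gives > 100000 nM, again a limit of the assay. Two of the three values thus sit at the limit of > 100000 nM in this assay, at which 2 of the 3 values shown sit.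

Compound 4 `O=C(/C=C/c1ccc(Cl)cc1)Nc1cc(Sc2ncn[nH]2)c(O)c2ccccc12` has not yet been measured. It differs from compound 2 by 2-(4-chlorophenyl)ethenyl in place of 4-chlorophenyl on a carbonyl carbon. Among the measured compounds shown here, no measured step reproduces this change directly; the one measured step, from compound 2 to compound 3, concerns the aryl substituent rather than the linker, while compound 1, which also has a double bond outside aromatic rings, reached only a limit. Compound 4 is therefore expected to shift toward weaker inhibition, by about a 1.8-fold higher number from compound 2 to compound 4 (0.27 log units; within the scatter), with a real chance that only a limit is reported. The estimate for compound 4 in this assay is 80000 nM, within a range of 30000 nM to 200000 nM.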

Compound 4, half-maximal inhibitory concentration: > 100000 nM
Compound 4: a limit, no number; the forecaster's own chance of this, stated with the estimate: 50%; middle value at least 1.2-fold (0.09 log units) away from the limit.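

In this assay, putting 2-(4-chlorophenyl)ethenyl in place of 4-chlorophenyl on the carbonyl carbon gives an at least 2.3-fold higher number from compound 2 to compound 4 (0.36 log units; beyond the scatter), so a change that keeps the chloro substituent also moves the result beyond the scatter. Compound 4 gives a limit of the assay, not a number, which fixes only the least size of this step; the steps from compound 3 and from compound 1 to compound 4 cannot be read, so the exchange of nitro for chloro on the aromatic carbon remains without a measured size. Compound 2 therefore remains the only member with a number, and the other three members offer no order among themselves: the limit of > 100000 nM in this assay, at which 3 of the 4 values shown sit.

The compounds shown leave open whether a saturated 2-(4-chlorophenyl)ethyl group on the carbonyl carbon would also end at this limit or would give a number. They also leave open whether an amine or a carboxylic acid on the aromatic ring, in place of the chloro of compound 2, would keep a measurable value in this assay.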